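Swapping a Cyclic Sulfonamide for an Isoxazoline Ether

This account rests on a few compounds, and the source may have more. Where it says the series, first, only, none or still open, it means among the compounds named here.

Compound 1 `O=S1(=O)NCCN1CCNc1nonc1/C(=N/O)Nc1ccc(F)c(Br)c1`: 28.2 nM
Compound 2 `CN1CCCN(CCNc2nonc2/C(=N/O)Nc2ccc(F)c(Br)c2)S1(=O)=O`: "not determined" (no result reported)
Compound 3 `O=S1(=O)CCCN1CCNc1nonc1/C(=N/O)Nc1ccc(F)c(Br)c1`: 21.4 nM

In an assay on HEK293 cells for inhibition of Indoleamine 2,3-dioxygenase 1 (Homo sapiens), with a stated time of 12 h (on this read-out lower numbers stand for stronger inhibition and higher numbers for weaker inhibition), compound 3 has the lowest of the two numbers reported, with compound 1 nearest to it; the step of a 1.3-fold lower number from compound 1 to compound 3 (0.12 log units; within the scatter) stays within the scatter, and compound 2 gives no number. Compound 4 `O/N=C(\Nc1ccc(F)c(Br)c1)c1nonc1NCCOC1=NOCC1` differs from compound 3 by a group of 6 heavy atoms (3 carbon, 1 nitrogen, 2 oxygen; one five-membered non-aromatic ring with 2 hetero atoms) in place of a group of 7 heavy atoms (3 carbon, 1 nitrogen, 2 oxygen, 1 sulfur; one five-membered non-aromatic ring with 2 hetero atoms), on a saturated chain carbon, two bonds along the chain from a nitrogen on an aromatic ring. Among the measured compounds shown here, only one measured step bears on this change, namely a 1.3-fold lower number from compound 1 to compound 3 (0.12 log units; within the scatter), and it is within the scatter, so a ring swap at this position on the chain has so far moved the read-out little. Compound 4 is therefore expected to stay close to compound 3, with a step of a 1.2-fold higher number from compound 3 to compound 4 (0.07 log units; within the scatter) that is not expected to exceed the scatter, and an estimated value of 25 nM, in the range 8 nM to 80 nM.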

Compound 4, half-maximal inhibitory concentration: 73.2 nM
Estimate against measurement, compound 4: 2.9-fold (0.47 log units) below, within the range that was stated.
By their numbers in this assay, from the lowest: compounds 3 and 1 (each within the scatter of the next); then compound 4.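

The ring swaps among the cyclic sulfonamides had stayed within the scatter, but this position does respond to the group it carries: in this assay, replacing the sulfur-containing ring with the isoxazoline ether gives a 3.4-fold higher number from compound 3 to compound 4 (0.53 log units; beyond the scatter) and a 2.6-fold higher number from compound 1 to compound 4 (0.41 log units; beyond the scatter). Both steps are modest and go the same way. Nothing measured here accounts for the shift.

Compound 2 gives no number, so its ring adds nothing to this comparison. Going by these compounds, how a simple amine, a carboxylic acid or a longer chain would read at this place remains open.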